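The source may report more compounds than this note shows. Statements on the series, on what has been measured and on what is new or still open speak of the compounds shown alone.

Measured so far in an ADME assay on Vero cells (Chlorocebus sabaeus) for cytotoxicity, read by MTT assay, with a stated time of 72 h; on this read-out higher numbers stand for lower toxicity in this test and lower numbers for higher toxicity in this test:
Compound 1, `Brc1ccc([C@@H]2C[C@@H]3Cc4ccc5ccccc5c4N2O3)cc1`, gives > 250000 nM, a limit of this assay rather than a number.
Compound 2, `Clc1ccccc1[C@@H]1C[C@@H]2Cc3ccc4ccccc4c3N1O2`, gives 37200 nM.

For the measured compounds named here, compound 2 thus holds the only actual number, the other value being a limit. Going by the values given here, the step of an at least 6.7-fold lower number from compound 1 to compound 2 (0.82 log units; beyond the scatter) is the sole comparison available, and it concerns the same phenyl ring. Compound 3, `Clc1ccc([C@@H]2C[C@@H]3Cc4ccc5ccccc5c4N2O3)c(Cl)c1`, differs from compound 2 by chloro in place of hydrogen on an aromatic carbon. Since that one step gives only a loose guide, compound 3 is expected to sit near compound 2, with the step of a 1.2-fold lower number from compound 2 to compound 3 (0.09 log units; within the scatter) not clearly beyond the scatter. Compound 3 is estimated at 30000 nM, between 10000 nM and 100000 nM.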

Compound 3, half-maximal cytotoxic concentration: 55000 nM
Estimate against measurement, compound 3: 1.8-fold (0.26 log units) below; the range from low to high includes it.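

In this assay, chloro in place of hydrogen on this aromatic carbon, para to a large group, gives a 1.5-fold higher number from compound 2 to compound 3 (0.17 log units; within the scatter), so compound 2 and compound 3 cannot be told apart here. The 2,4-dichlorophenyl group nevertheless stays clearly apart from the 4-bromophenyl group, with an at least 4.5-fold lower number from compound 1 to compound 3 (0.65 log units; beyond the scatter). That step is open-ended, as the value of compound 1 is a limit of the assay: the limit of > 250000 nM in this assay, at which 1 of the 3 values shown sits.

Left open is how a 4-chlorophenyl group would compare with the 4-bromophenyl group. Also open, going by these compounds, is whether an amine or a carboxylic acid on this carbon would move the number.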